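The source may hold more compounds than are shown below. What is called first, only, known or untested is meant among the compounds shown, and "the series" means these compounds.

Measured so far in a functional assay on RS4-11 cells (Homo sapiens) for inhibition, read by CCK-8 assay, with a stated time of 48 h, tested at 20 uM; a higher number here means more inhibition of growth at the concentration tested, a lower number less inhibition of growth:

compound 1 `Cc1ccc(S(=O)(=O)Oc2ccccc2/C=C(\C#N)C(=O)Nc2nnc(C)s2)cc1`, which gives 33%
compound 2 `COc1ccc(Cc2nnc(NC(=O)/C(C#N)=C/c3ccccc3OS(=O)(=O)c3ccc(C)cc3)s2)cc1`, which gives 70%

Among the compounds with values here, compound 2 stands highest of the two numbers, and its only neighbour, compound 1, lies well below it. Within the data shown here, the single measured step, a number 37 percentage points higher from compound 1 to compound 2 (beyond the scatter), is large and beyond the scatter; it comes from 4-methoxyphenyl in place of hydrogen on a saturated chain carbon bound to an aromatic carbon, so it concerns the substituent on the thiadiazole-side chain and not the sulfonyl ester end of the molecule.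

Compound 3 `COc1ccc(Cc2nnc(NC(=O)/C(C#N)=C/c3ccccc3OS(=O)(=O)c3ccc([N+](=O)[O-])cc3)s2)cc1` is the next member and differs from compound 2 by nitro in place of methyl on an aromatic carbon. Among the measured compounds shown here, this change sits on the (4-methylphenyl)sulfonyl part, a part that no measured step touches. For the measured compounds named here, the one step available therefore bears nothing on it, and there is no basis in these two compounds for expecting a move in either direction. The expected step is a number 5 percentage points lower from compound 2 to compound 3 (within the scatter), nothing beyond the scatter. Compound 3 is thus estimated at 65% in this assay, with a range from 40% to 85%.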

Compound 3, percent growth inhibition at one concentration: 70%
For compound 3 the middle estimate is 5 percentage points below the measured one; the measured number falls inside the stated range.
By their numbers in this assay, from the lowest: compound 1; then compounds 2 and 3 (each within the scatter of the next).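

In this assay, the series now has a step at the (4-methylphenyl)sulfonyl part, which the earlier pair left untouched: nitro in place of methyl on an aromatic carbon, para to a large group, gives no change at the digits printed from compound 2 to compound 3 (within the scatter). This position therefore takes nitro for methyl with no difference beyond the scatter, at least with the 4-methoxyphenyl group of compound 2 and compound 3 in place, whereas a number 37 percentage points higher from compound 1 to compound 2 (beyond the scatter) remains the only step beyond the scatter in the compounds shown. Nothing on hand offers an explanation for this flat result.

From the compounds shown here alone, it remains open whether the same position would give a similar reading with an amine, a carboxylic acid or a plain hydrogen in place of methyl or nitro, as one pair cannot establish a general tolerance there. Also open, going by these compounds, is whether nitro for methyl would read the same with the smaller methyl group of compound 1 at the other end of the molecule, and how compound 2 and compound 3 compare at other concentrations.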